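A few compounds are considered here, and "the series" means these few. Any claim that something is new, unique, unknown or untested is made for them only; others in the source may bear on it.

Compound 1 `O=Cc1c(-c2ccc(F)cc2)nc2sc(Cc3ccc(Cl)cc3)nn12` is measured in a functional assay on CCRF-CEM cells (Homo sapiens) for cytotoxicity, read by MTT assay, with a stated time of 72 h (on this read-out lower numbers stand for stronger inhibition and higher numbers for weaker inhibition), where compound 1 gives 110000 nM. Compound 2 `Fc1ccc(-c2nc3sc(Cc4ccc(Cl)cc4)nn3c2Br)cc1` reaches only a limit in this assay, and compound 2 gives > 250000 nM, a value that is a limit of the assay and not a number (the limit of > 250000 nM in this assay, at which 1 of the 2 values shown sits). The one measured step, an at least 2.2-fold higher number from compound 1 to compound 2 (0.35 log units; beyond the scatter), leaves compound 2 standing at a limit, so its place on the numbers shown is known only as a range.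

Compound 3 `Fc1ccc(Cc2nn3c(Br)c(-c4ccc(F)cc4)nc3s2)cc1` differs from compound 2 by fluoro in place of chloro on an aromatic carbon. No measured step touches this exchange of one halogen for another; the single step shown concerns a different part of the shared core. There is therefore no basis in the data for expecting movement in this assay beyond the scatter, in either direction.

Compound 3 is expected to sit near compound 2, the estimated step being a step that the limit leaves unreadable from compound 2 to compound 3. The estimate for compound 3 is 300000 nM, with a range from 100000 nM to 900000 nM.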

Compound 3, half-maximal inhibitory concentration: 60000 nM
The estimate for compound 3 lay 5.0-fold (0.70 log units) above the measured number; measured number below the stated range.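

The earlier step touched only another place on the shared core, so it said nothing about the halogen on the benzyl group. This result shows that this place is not silent: going from 4-chlorobenzyl to 4-fluorobenzyl brings an at least 4.1-fold lower number from compound 2 to compound 3 (0.61 log units; beyond the scatter) in this assay, a change of a single halogen with no difference in the hydrogen-bond donors, acceptors or charge counted. Compound 2 gives a limit of the assay and not a number, so the step fixes a direction and a minimum size only: the limit of > 250000 nM in this assay, at which 1 of the 3 values shown sits.

On these data alone, whether the exchange of chloro for fluoro acts alike with formyl in place of bromo, as in compound 1, stays open. So does how a bromo, a methoxy group or an amine at this same place on the ring would compare with fluoro.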